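Nitrophenyl variant of the hydroxybenzylidene-thiadiazole series

The source may report more compounds than this note shows. Statements on the series, on what has been measured and on what is new or still open speak of the compounds shown alone.

Measured so far:
compound 1 `Oc1ccccc1/C=N/c1nnc(SCc2nnc(-c3ccc(F)cc3)o2)s1`: 13100 nM
compound 2 `Oc1ccccc1/C=N/c1nnc(SCc2nnc(-c3ccc(Br)cc3)o2)s1`: 18000 nM
compound 3 `Cc1ccc(-c2nnc(CSc3nnc(/N=C/c4ccccc4O)s3)o2)cc1`: 37100 nM

In a functional assay on SMMC-7721 cells (Homo sapiens) for inhibition, read by CCK-8 assay (on this read-out higher numbers stand for weaker inhibition and lower numbers for stronger inhibition), compound 1 gives the lowest of the three numbers. Its nearest neighbour is compound 2, reached by a 1.4-fold higher number from compound 1 to compound 2 (0.14 log units; within the scatter), so the two cannot be ordered. Compound 3 stands furthest, by a 2.8-fold higher number from compound 1 to compound 3 (0.45 log units; beyond the scatter), and also a 2.1-fold higher number from compound 2 to compound 3 (0.31 log units; beyond the scatter) points the same way; both are modest shifts.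

Compound 4 `O=[N+]([O-])c1cccc(-c2nnc(CSc3nnc(/N=C/c4ccccc4O)s3)o2)c1` is not yet measured. It differs from compound 1 as follows: 3-nitrophenyl in place of 4-fluorophenyl on an aromatic carbon. Going by the values given here, none of the measured steps involves a nitro group, and the measured changes all sit at the same place on the phenyl ring as each other, so the only guidance is that swapping the halogen for methyl weakened inhibition modestly, while swapping one halogen for another did not move the number beyond the scatter. For compound 4 the step of a 1.2-fold higher number from compound 1 to compound 4 (0.09 log units; within the scatter) is therefore expected to be small, with no clear direction beyond the scatter. The estimate for compound 4 in this assay is 16000 nM, within a range from 6000 nM to 45000 nM.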

Compound 4, half-maximal inhibitory concentration: 15700 nM
Compound 4: the middle estimate sits 1.0-fold (0.01 log units) above what was measured; the range from low to high includes it.
By their numbers in this assay, from the lowest: compounds 1, 4 and 2 (each within the scatter of the next); then compound 3.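

In this assay, this position takes 3-nitrophenyl in place of 4-fluorophenyl with a 1.2-fold higher number from compound 1 to compound 4 (0.08 log units; within the scatter), and the comparison with 4-bromophenyl gives a 1.1-fold lower number from compound 2 to compound 4 (0.06 log units; within the scatter), so a group bearing hydrogen-bond acceptors and more heavy atoms cannot be told apart from either halogen. Against 4-methylphenyl the same group gives a 2.4-fold lower number from compound 3 to compound 4 (0.37 log units; beyond the scatter), which leaves compound 3 as the only one of the four set apart from the rest, and no longer just by comparison with the two halogens. No measurement shown offers an explanation for this pattern.

The step from 4-fluorophenyl to 3-nitrophenyl changes both the group and its place on the phenyl ring, and the compounds shown do not separate the two. Going by these compounds, how an amine or a carboxylic acid on that phenyl ring would read remains open.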